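Benzyl for Phenyl on a Second Five-Membered Ring

The source may report more compounds than this note shows. Statements on the series, on what has been measured and on what is new or still open speak of the compounds shown alone.

Compound 1 `O=C1NC(=O)/C(=C/c2ccc(OCCSc3nnc(-c4ccccc4)[nH]3)cc2)S1` and compound 2 `O=C1NC(=O)/C(=C/c2ccc(OCCSc3nnc(Cc4ccccc4)[nH]3)cc2)S1` share a core carrying a five-membered aromatic ring with 3 nitrogen, while compound 3 `O=C1NC(=O)/C(=C/c2ccc(OCCSc3nnc(-c4ccccc4)o3)cc2)S1` and compound 4 `O=C1NC(=O)/C(=C/c2ccc(OCCSc3nnc(Cc4ccccc4)o3)cc2)S1` carry one with 2 nitrogen and 1 oxygen; the difference between the two cores is not broken down here. In a functional assay on the whole organism (strain Wistar) with Rattus norvegicus as the target, with a stated time of 15 days, at a dose of 100 mg/kg by the oral route (a lower number here means a weaker effect, a higher number a stronger effect of the compound at the dose given), compound 1 gives 38.9%, compound 2 gives 41.9%, and compound 3 gives 33.1%. The change benzyl in place of phenyl on an aromatic carbon made a step of a number 3 percentage points higher from compound 1 to compound 2 (within the scatter). The same kind of change, (benzyl in place of phenyl on an aromatic carbon), turns compound 3 into compound 4; the place differs in that the ring carbon lies next to the ring oxygen rather than between two ring nitrogen atoms. Because the step of a number 3 percentage points higher from compound 1 to compound 2 (within the scatter) stayed within the scatter, compound 4 is expected to shift by about a number 2.9 percentage points higher from compound 3 to compound 4 (within the scatter). Compound 4 is therefore estimated at 36%, between 26% and 46%.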

Compound 4, a percentage reported as activity, at one dose (the size of the read-out at that dose, not a potency): 34.6%
Estimate against measurement, compound 4: 1.4 percentage points above, within the range that was stated.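

In this assay, benzyl in place of phenyl on an aromatic carbon made a step of a number 1.5 percentage points higher from compound 3 to compound 4 (within the scatter), and this step can be set beside the earlier one: the same change on two cores in this assay, a number 3 percentage points higher (within the scatter) from compound 1 to compound 2 and a number 1.5 percentage points higher (within the scatter) from compound 3 to compound 4, 1.5 percentage points apart, within the scatter of two such steps.
The change therefore carries from one core to the other in the limited sense that it stays within the scatter on both. This does not show that benzyl and phenyl are interchangeable on other cores or at other doses, and steps this small establish no shared effect of the change.

In this assay the compounds shown leave open whether a longer chain, such as phenethyl, in place of benzyl would move the read-out beyond the scatter. They also leave open what an amine or a carboxylic acid on the benzyl ring would do.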